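A few compounds are considered here, and "the series" means these few. Any claim that something is new, unique, unknown or untested is made for them only; others in the source may bear on it.

Compound 1 `O=C(Nc1[nH]nc(-c2ccccn2)c1C1CC1)c1ccccc1F`: > 100 mL.min-1.g-1
Compound 2 `N#Cc1ccc(C2CCN(C(=O)Nc3cc(-c4ccccn4)n[nH]3)CC2)cc1`: 80.8 mL.min-1.g-1

Both results come from an ADME assay on liver (Mesocricetus auratus) for metabolic stability, using microsomes; a lower number here means slower removal, a higher number faster removal of the compound. The result for compound 1 is a limit of the assay and not a number. Among the compounds with values here, compound 2, at 80.8 mL.min-1.g-1, therefore holds the only numerical value so far, and no measured step between close relatives is available to guide a prediction.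

Compound 3 `O=C(Nc1cc(-c2ccccn2)n[nH]1)N1CCC(Oc2ccccn2)CC1` has not yet been measured. It differs from compound 2 by carrying (pyridin-2-yl)oxy in place of 4-cyanophenyl on a saturated ring carbon. With compound 2 at 80.8 mL.min-1.g-1 as the only numerical starting point, the expected 1.2-fold lower number from compound 2 to compound 3 (0.06 log units; within the scatter) is none beyond the scatter, in either direction. For compound 3 the estimated clearance is 70 mL.min-1.g-1, with an expected range of 30 mL.min-1.g-1 to 100 mL.min-1.g-1.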

Compound 3, intrinsic clearance in microsomes: 67.3 mL.min-1.g-1
Compound 3: middle estimate off by 1.0-fold (0.02 log units), on the high side; measured number inside the range.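

In this assay, within the data shown here, putting (pyridin-2-yl)oxy in place of 4-cyanophenyl on a saturated ring carbon gives a 1.2-fold lower number from compound 2 to compound 3 (0.08 log units; within the scatter) and so provides the first measured step at this position. This single pair shows that a six-membered aromatic ring of carbon only bearing a nitrile and a six-membered aromatic ring with 1 hetero atom, carried through an oxygen, cannot be told apart in this read-out. The exchange also alters the number of hydrogen-bond acceptors on the group without a change beyond the scatter in this pair.

The compounds shown leave open whether an amine, a carboxylic acid or a longer chain on this ring carbon would read differently. Compound 1 is a limit and not a number, and it differs from the other compounds in more than one place: the limit of > 100 mL.min-1.g-1 in this assay, at which 1 of the 3 values shown sits.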